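The source may report more compounds than this note shows. Statements on the series, on what has been measured and on what is new or still open speak of the compounds shown alone.

Measured compounds:
- compound 1 `Cc1cccc(N2CCC(C(=O)Nc3ccc4c(c3)NC(=O)CO4)CC2)c1`: 225 nM
- compound 2 `O=C1COc2ccc(NC(=O)C3CCN(c4ccccc4C(F)(F)F)CC3)cc2N1`: 68 nM
- compound 3 `Cc1c(Cl)cccc1N1CCC(C(=O)Nc2ccc3c(c2)NC(=O)CO3)CC1`: 100 nM

In an assay on HEK293 cells for displacement of a labelled ligand from transient receptor potential cation channel subfamily V member 1 (Homo sapiens) (a higher number here means a weaker inhibitor, a lower number a stronger inhibitor), compound 3 gives 100 nM, the second highest of the three numbers. Its nearest neighbour is compound 2, which in this assay gives 68 nM; the step of a 1.5-fold higher number from compound 2 to compound 3 (0.17 log units; within the scatter) lies within the scatter. Compound 1 gives 225 nM, and the step of a 2.3-fold lower number from compound 1 to compound 3 (0.35 log units; beyond the scatter) stands beyond the scatter.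

Compound 4 `O=C1COc2ccc(NC(=O)C3CCN(c4ccccc4Cl)CC3)cc2N1` has not yet been measured. It differs from compound 3 in one place: 2-chlorophenyl in place of 3-chloro-2-methylphenyl on an amine nitrogen in a ring. Among the compounds with values here, two measured steps bear on this. The step of a 2.3-fold lower number from compound 1 to compound 3 (0.35 log units; beyond the scatter) shows that moving from 3-methylphenyl to 3-chloro-2-methylphenyl lowered the number modestly, and the step of a 1.5-fold higher number from compound 2 to compound 3 (0.17 log units; within the scatter) shows that 2-(trifluoromethyl)phenyl and 3-chloro-2-methylphenyl give numbers within the scatter of each other. Compound 2, which carries the 2-(trifluoromethyl)phenyl group, is the closest measured relative of the 2-chlorophenyl group entering in compound 4. Within the data shown here, no step directly tests 2-chlorophenyl.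

On this basis compound 4 is expected to give a number close to that of compound 3, with the step of a 1.1-fold higher number from compound 3 to compound 4 (0.04 log units; within the scatter) expected to stay within the scatter. The estimate for compound 4 in this assay is 110 nM, with a range from 45 nM to 270 nM.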

Compound 4, inhibition constant: 93 nM
Compound 4: middle estimate off by 1.2-fold (0.07 log units), on the high side; low and high end bracket the measured number.
By their numbers in this assay, from the lowest: compounds 2, 4 and 3 (each within the scatter of the next); then compound 1.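

Within the data shown here, with compound 4, one substituent on the aromatic ring can be exchanged directly for the first time: in this assay, the step of a 1.4-fold higher number from compound 2 to compound 4 (0.14 log units; within the scatter) puts chloro in place of trifluoromethyl on an aromatic carbon and leaves the two numbers within the scatter of each other. The step of a 1.1-fold lower number from compound 3 to compound 4 (0.03 log units; within the scatter) shows that 2-chlorophenyl can also stand in place of 3-chloro-2-methylphenyl on the amine nitrogen without a change beyond the scatter. Among these four compounds, 2-chlorophenyl, 2-(trifluoromethyl)phenyl and 3-chloro-2-methylphenyl therefore form one group of numbers within the scatter of each other, while the step of a 2.4-fold lower number from compound 1 to compound 4 (0.38 log units; beyond the scatter) sets 3-methylphenyl apart from 2-chlorophenyl, as it already stood apart from the other two groups.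

No measurement other than these numbers is at hand to account for how closely the three groups agree. The compounds shown leave open how an unsubstituted phenyl, a 2-methylphenyl or a 2-methoxyphenyl would compare at this position, and whether the same agreement would hold with any change to the shared core.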